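Replacing an aromatic acyl group with cyclohexyl: expected toxicity

This account rests on a few compounds, and the source may have more. Where it says the series, first, only, none or still open, it means among the compounds named here.

Measured so far:
Compound 1, `NC(=S)N1CCc2c(OCCCCCOc3ccc(Cl)cc3)cccc21`: in an ADME assay on Huh-7 cells (Homo sapiens) for cytotoxicity (on this read-out higher numbers stand for lower toxicity in this test and lower numbers for higher toxicity in this test), compound 1 reaches only a limit of the test, > 50000 nM.
Compound 2, `NC(=S)n1ccc2c(OCCCCCOc3ccc(Cl)cc3)cccc21`: in this assay compound 2 gives 24700 nM.
Compound 3, `O=C(NC(=S)N1CCc2c(OCCCCCOc3ccc(Cl)cc3)cccc21)c1ccc(C(F)(F)F)cc1`: in this assay compound 3 gives 32700 nM.

Compound 3 holds the highest of the two actual numbers in this assay, but its gap to compound 2 lies within the scatter, so the two cannot be told apart. The value of compound 1 is a limit and not a number (the limit of > 50000 nM in this assay, at which 1 of the 3 values shown sits).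

Compound 4, `O=C(NC(=S)N1CCc2c(OCCCCCOc3ccc(Cl)cc3)cccc21)C1CCCCC1`, differs from compound 3 in one place: cyclohexyl in place of 4-(trifluoromethyl)phenyl on a carbonyl carbon. Among the measured compounds shown here, only one measured step bears on this region of the molecule, an at least 1.5-fold lower number from compound 1 to compound 3 (0.18 log units; that floor lies within the scatter), which put the aromatic acyl group onto the amide-type nitrogen of compound 1 and gave a step whose floor lies within the scatter. For the measured compounds named here, no measured step compares an aromatic ring with a saturated ring at this carbonyl carbon. Going by the values given here, with the sole nearby step being small, no change beyond the scatter is expected in this assay, so for compound 4 the expected step is a 1.1-fold lower number from compound 3 to compound 4 (0.04 log units; within the scatter). Compound 4 is therefore estimated at 30000 nM, within a range from 12000 nM to 75000 nM.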

Compound 4, half-maximal cytotoxic concentration: > 50000 nM
Compound 4: only a limit was reported (the forecaster's own chance of this, stated with the estimate: 25%); at least 1.6-fold (0.22 log units) between middle value and limit.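

Putting cyclohexyl in place of 4-(trifluoromethyl)phenyl on the carbonyl carbon gives, in this assay, an at least 1.5-fold higher number from compound 3 to compound 4 (0.18 log units; that floor lies within the scatter), so this carbonyl carbon can now be seen to carry a saturated ring as well as an aromatic one, but the data do not show a real difference between the two. Going by these compounds, compound 4 has only a limit in this test, > 50000 nM, and not a number, so the true size of the change remains unknown. The step between compound 1 and compound 4 cannot be read, and the two compounds cannot be ranked against each other, since both stop at the same limit: the limit of > 50000 nM in this assay, at which 2 of the 4 values shown sit.

The swap also changes two things at once, the ring type and the loss of the trifluoromethyl group, and a plain phenyl on the carbonyl carbon would be needed to tell these two changes apart. On these data alone, it also remains open how this read-out would respond to a much smaller group there, such as methyl, or to a ring or chain carrying an amine or a carboxylic acid.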